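This account rests on a few compounds, and the source may have more. Where it says the series, first, only, none or still open, it means among the compounds named here.

Among the three measured compounds, in a functional assay for inhibition, with Homo sapiens as the target (on this read-out lower numbers stand for stronger inhibition and higher numbers for weaker inhibition), compound 3 (`CC1(C)COC(c2cc(-c3ccoc3)c3ccc(OCc4cccc(C5(O)CCOCC5)c4)cc3c2)=N1`) gives 17 nM, between compound 1 (`COC(=O)c1cc(-c2ccccc2)c2ccc(OCc3cccc(C4(O)CCOCC4)c3)cc2c1`) at 3 nM and compound 2 (`O=C(O)c1cc(-c2ccccc2)c2ccc(OCc3cccc(C4(O)CCOCC4)c3)cc2c1`) at 190 nM. Compound 4 (`OC1(c2cccc(COc3ccc4c(-c5ccoc5)cc(Cc5nccs5)cc4c3)c2)CCOCC1`) departs from compound 3 at one place: a group of 6 heavy atoms (4 carbon, 1 nitrogen, 1 sulfur; one five-membered aromatic ring with 2 hetero atoms) in place of a group of 7 heavy atoms (5 carbon, 1 nitrogen, 1 oxygen; one five-membered non-aromatic ring with 2 hetero atoms), on an aromatic carbon. The five-membered non-aromatic ring thus gives way to (1,3-thiazol-2-yl)methyl, meta to a furan-3-yl group.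

Among the measured compounds shown here, only one measured step bears on this place, and only indirectly: a 63-fold higher number from compound 1 to compound 2 (1.80 log units; beyond the scatter), with hydrogen in place of methyl on an oxygen next to a carbonyl group. That large step shows that this assay can respond strongly to a change here. For the measured compounds named here, it does not, however, test the present exchange, and no measured pair does. Both groups in the present exchange carry no net charge, so a modest change with no firm direction is expected. The expected step is a 1.2-fold higher number from compound 3 to compound 4 (0.07 log units; within the scatter), which lies within the uncertainty of this estimate. For compound 4 the estimated value is 20 nM, with an expected range of 5 nM to 80 nM.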

Compound 4, half-maximal inhibitory concentration: 1 nM
Compound 4: middle estimate off by 20-fold (1.30 log units), on the high side; measured number outside the range, below it.
By their numbers in this assay, from the lowest: compound 4; then compound 1; then compound 3; then compound 2.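

In this assay, (1,3-thiazol-2-yl)methyl in place of the five-membered non-aromatic ring on this aromatic carbon gives a 17-fold lower number from compound 3 to compound 4 (1.23 log units; beyond the scatter), a large step beyond the scatter towards stronger inhibition. The earlier pair had shown only a loss at this place, with hydrogen in place of methyl on the oxygen next to the carbonyl, whereas this exchange shows that a change here can also lower the number substantially, at least with a furan-3-yl group on the same ring. No measurement given here accounts for the size or direction of this step.

The compounds shown leave open whether the lower number goes with the thiazole ring itself or with the methyl carbon that attaches it. They also leave open how a benzyl group or an amine would behave at this position.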